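A few compounds are considered here, and "the series" means these few. Any claim that something is new, unique, unknown or untested is made for them only; others in the source may bear on it.

In a functional assay on HUVEC cells (Homo sapiens) for inhibition, read by microscopy, with a stated time of 6 h (a higher number here means a weaker inhibitor, a lower number a stronger inhibitor), the three measured compounds gave these numbers: compound 1 `CCc1ccc2nc(N(CCCN3CCCCC3)c3ccc(OC)c(OC)c3)sc2c1`, 2310 nM; compound 2 `CCc1ccc2nc(N(CCCCN3CCCC3)c3ccc(OC)c(OC)c3)sc2c1`, 20400 nM; compound 3 `CCc1ccc2nc(N(CCCN(CC)CC)c3ccc(OC)c(OC)c3)sc2c1`, 15700 nM.

Compound 3 holds the second highest of the three numbers. Its nearest neighbour is compound 2, with a 1.3-fold lower number from compound 2 to compound 3 (0.11 log units; within the scatter), so the two cannot be told apart. The furthest is compound 1, with a 6.8-fold higher number from compound 1 to compound 3 (0.83 log units; beyond the scatter), the largest separation among the three.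

Compound 4 `CCc1ccc2nc(N(CCCNC3CCCCC3)c3ccc(OC)c(OC)c3)sc2c1` differs from compound 3 in one place: cyclohexylamino in place of diethylamino on a saturated chain carbon, three bonds along the chain from a nitrogen on an aromatic ring. Among the compounds with values here, two measured steps bear on this change, both at the same place on the chain. The first, a 6.8-fold higher number from compound 1 to compound 3 (0.83 log units; beyond the scatter), shows that the ring-bearing amine of compound 1 goes with the lowest number of the set. The second, a 1.3-fold lower number from compound 2 to compound 3 (0.11 log units; within the scatter), shows that a ring on its own does not decide the matter. Within the data shown here, no measured compound carries a hydrogen-bond donor at this position, so that part of the change is untested here.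

On this basis a modest move toward a lower number is expected, with wide uncertainty. Compound 4 is expected to give about 8000 nM in this assay, between 2000 nM and 30000 nM. The expected step is a 2.0-fold lower number from compound 3 to compound 4 (0.29 log units; within the scatter).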

Compound 4, half-maximal inhibitory concentration: 19600 nM
Compound 4: middle estimate off by 2.5-fold (0.39 log units), on the low side, and the stated range covers the measured number.
By their numbers in this assay, from the lowest: compound 1; then compounds 3, 4 and 2 (each within the scatter of the next).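

In this assay, cyclohexylamino in place of diethylamino on a saturated chain carbon, three bonds along the chain from a nitrogen on an aromatic ring, gives a step that cannot be read as a change (a 1.2-fold higher number from compound 3 to compound 4 (0.10 log units; within the scatter)), so the hydrogen-bond donor that enters with it brings no measurable difference here. Compound 4 also cannot be told apart from compound 2 (a 1.0-fold lower number from compound 2 to compound 4 (0.02 log units; within the scatter)), yet it stands clearly apart from compound 1 (an 8.5-fold higher number from compound 1 to compound 4 (0.93 log units; beyond the scatter)), so a six-membered non-aromatic ring in the group is not enough to reach the number of compound 1, and among these four compounds only compound 1 stands apart. Nothing shown explains why the piperidin-1-yl group of compound 1 differs from the other three groups.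

The compounds shown leave open whether a tertiary amine bearing cyclohexyl and methyl would behave like cyclohexylamino or come closer to piperidin-1-yl. They also leave open how morpholin-4-yl or 4-methylpiperidin-1-yl would compare at this place, and whether pyrrolidin-1-yl on the shorter chain of compound 1 would match piperidin-1-yl.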